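Shortening the alkyl chain: from compound 2 to compound 3

A few compounds are considered here, and "the series" means these few. Any claim that something is new, unique, unknown or untested is made for them only; others in the source may bear on it.

compound 1 `CCCCCCCCCCCCCC/N=c1\nc(N)c2ncn(Cc3ccccc3)c2c(N)n1` — 4200 nM
compound 2 `CCCCCCCCCC/N=c1\nc(N)c2ncn(Cc3ccccc3)c2c(N)n1` — 5150 nM

In a functional assay on PC-3 cells (Homo sapiens) for antiproliferative activity, read by WST assay, with a stated time of 72 h (a higher number here means a weaker inhibitor, a lower number a stronger inhibitor), compound 1 gives 4200 nM and compound 2 gives 5150 nM. The step of a 1.2-fold higher number from compound 1 to compound 2 (0.09 log units; within the scatter) falls within the scatter, so the two numbers cannot be told apart, and compound 2 is simply one of two indistinguishable values. Compound 3 `CCCCCCCC/N=c1\nc(N)c2ncn(Cc3ccccc3)c2c(N)n1` remains unmeasured; it differs from compound 2 by hydrogen in place of ethyl on a saturated chain carbon, eight bonds along the chain from a double-bonded nitrogen. Among the measured compounds shown here, the single step that bears on this change is a 1.2-fold higher number from compound 1 to compound 2 (0.09 log units; within the scatter), a shortening of the same chain, and it stayed within the scatter. A shift no larger than the scatter is therefore expected in this assay. Compound 3 is estimated at 6500 nM with a range from 3200 nM to 14000 nM, meaning an expected step of a 1.3-fold higher number from compound 2 to compound 3 (0.10 log units; within the scatter).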

Compound 3, half-maximal inhibitory concentration: 5930 nM
Compound 3: middle estimate off by 1.1-fold (0.04 log units), on the high side; measured number inside the range.
By their numbers in this assay, from the lowest: compounds 1, 2 and 3 (each within the scatter of the next).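

In this assay, hydrogen in place of ethyl gives a 1.2-fold higher number from compound 2 to compound 3 (0.06 log units; within the scatter). The larger cut at the same place, hydrogen in place of hexyl, gives a 1.4-fold higher number from compound 1 to compound 3 (0.15 log units; within the scatter), so even this wider span of chain lengths leaves compound 1, compound 2 and compound 3 indistinguishable. No available measurement speaks to the reason for this flat response. Still open, on these data alone, is whether a much shorter chain, or an amine or a carboxylic acid on the chain, would give a number beyond the scatter.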